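This account rests on a few compounds, and the source may have more. Where it says the series, first, only, none or still open, it means among the compounds named here.

Measured so far:
Compound 1 `O=C(CSc1nnc(-c2ccncc2)s1)NCc1ccccc1Cl`: "not determined" (no result reported)
Compound 2 `CC(CSc1nnc(-c2ccncc2)s1)C(=O)NCc1ccccc1`: > 50000 nM

In an ADME assay on BHK-21 cells (Mesocricetus auratus) for cytotoxicity, with a stated time of 3 days (on this read-out lower numbers stand for higher toxicity in this test and higher numbers for lower toxicity in this test), compound 1 has no result. Compound 2 gives only a limit of the assay, > 50000 nM; the evidence here rests on (the limit of > 50000 nM in this assay, at which 1 of the 2 values shown sits). The piece follows the step from compound 1 to compound 3 `O=C(CSc1nnc(-c2ccncc2)s1)NCc1ccccc1`, in which (hydrogen in place of chloro on an aromatic carbon). For the measured compounds named here, since no measured step bears on this change, no shift beyond the usual scatter is expected in this assay. Compound 3 is expected to give about 50000 nM, within 20000 nM to 100000 nM, most likely reported only as a limit.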

Compound 3, half-maximal cytotoxic concentration: 11300 nM
Compound 3: middle estimate off by 4.4-fold (0.65 log units), on the high side; measured number below the stated range.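

Compound 1 has no number to set against compound 3, so no step can be read from this pair. The compounds shown leave open whether exchanging chloro for hydrogen shifts the half-maximal cytotoxic concentration at all.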